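Swapping the pyridinyl arm for a methylindolyl arm

The source may hold more compounds than are shown below. What is called first, only, known or untested is meant among the compounds shown, and "the series" means these compounds.

Compound 1 `Cn1c(=O)c(S(=O)(=O)c2ccc(F)cc2F)cc2cnc(Nc3ccc4occc4c3)nc21`: 15000 nM
Compound 2 `Cn1ccc2cc(Nc3ncc4cc(S(=O)(=O)c5ccc(F)cc5F)c(=O)n(C)c4n3)ccc21`: 750 nM
Compound 3 `Cn1c(=O)c(S(=O)(=O)c2ccc(F)cc2F)cc2cnc(Nc3ccccn3)nc21`: 35000 nM

These three compounds were tested in a functional assay on K562 cells (Homo sapiens) for inhibition, read by trypan blue exclusion, with a stated time of 72 h; on this read-out lower numbers stand for stronger inhibition and higher numbers for weaker inhibition. Compound 3 gives the highest number of the three, so it is the weakest inhibitor here: compound 1 lies closer, by a 2.3-fold higher number from compound 1 to compound 3 (0.37 log units; beyond the scatter), and compound 2 lies far away, by a 47-fold higher number from compound 2 to compound 3 (1.67 log units; beyond the scatter).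

Compound 4 `Cc1cc2cc(Nc3ncc4cc(S(=O)(=O)c5ccc(F)cc5F)c(=O)n(C)c4n3)ccc2[nH]1` has not yet been measured. It differs from compound 3 in one place: 2-methyl-1H-indol-5-yl in place of pyridin-2-yl on a nitrogen on an aromatic ring.

For the measured compounds named here, the step that bears most directly on this change is the one between compound 2 and compound 3, where a bicyclic indolyl group in place of the pyridinyl group went with a 47-fold higher number from compound 2 to compound 3 (1.67 log units; beyond the scatter). The step of a 20-fold lower number from compound 1 to compound 2 (1.30 log units; beyond the scatter) also shows that a bicyclic group of this kind can give a markedly lower number. Compound 4 carries a closely related indolyl group, so a large drop in this assay is expected, though not necessarily the full size seen for compound 2. For compound 4 the expected step is an 18-fold lower number from compound 3 to compound 4 (1.24 log units; beyond the scatter), giving an estimated value of 2000 nM, with a range from 500 nM to 10000 nM.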

Compound 4, half-maximal inhibitory concentration: 750 nM
The estimate for compound 4 lay 2.7-fold (0.43 log units) above the measured number; the measured number falls inside the stated range.
By their numbers in this assay, from the lowest: compounds 2 and 4 (each within the scatter of the next); then compound 1; then compound 3.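

In this assay, compound 4 shows that the low number is not tied to a single indolyl group: 2-methyl-1H-indol-5-yl and 1-methyl-1H-indol-5-yl cannot be told apart (no change at the digits printed from compound 2 to compound 4 (within the scatter)). Compound 4 also stands well clear of the pyridin-2-yl compound (a 47-fold lower number from compound 3 to compound 4 (1.67 log units; beyond the scatter)) and the 1-benzofuran-5-yl compound (a 20-fold lower number from compound 1 to compound 4 (1.30 log units; beyond the scatter)), so two indolyl compounds now share this lead, while compound 1 shows that having two fused rings is not enough on its own. Nothing measured here explains why the indolyl groups give lower numbers.

The compounds shown leave open how the plain 1H-indol-5-yl group, with no methyl, would compare. They also leave open whether an indolyl group can carry a longer chain, an amine or a carboxylic acid and keep this number.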